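Repeating a Small Swap on a Weaker Core

The source may hold more compounds than are shown below. What is called first, only, known or untested is meant among the compounds shown, and "the series" means these compounds.

Compound 1 `COc1cc(NC(C)CCCNC(=O)Nc2cccc(F)c2)c2ncccc2c1` and compound 3 `COc1cc(NC(C)CCCNC(=O)Nc2cccc(C(F)(F)F)c2)c2ncccc2c1` share one core and differ in a single way: trifluoromethyl in place of fluoro on an aromatic carbon. In a functional assay on MOLT-4 cells (Homo sapiens) for inhibition, read by MTT assay, with a stated time of 72 h (on this read-out lower numbers stand for stronger inhibition and higher numbers for weaker inhibition), compound 1 gives 23000 nM, while compound 3 gives 20000 nM, a step of a 1.2-fold lower number from compound 1 to compound 3 (0.06 log units; within the scatter). Compound 2 `COc1cc(NC(C)CCCNC(=O)NNC(=O)Nc2cccc(F)c2)c2ncccc2c1` stands on a different core, set apart from compound 1 by ((3-fluorophenyl)carbamoyl)amino in place of 3-fluorophenyl on an amide-type nitrogen, a change that brought an at least 10-fold higher number from compound 1 to compound 2 (1.03 log units; beyond the scatter). In this assay compound 2 yields only a limit, >= 250000 nM, which is the limit of >= 250000 nM in this assay, at which 1 of the 3 values shown sits. Compound 4 `COc1cc(NC(C)CCCNC(=O)NNC(=O)Nc2cccc(C(F)(F)F)c2)c2ncccc2c1` is not yet measured; it differs from compound 2 by trifluoromethyl in place of fluoro on an aromatic carbon, the same change as from compound 1 to compound 3, at the same place. Because a 1.2-fold lower number from compound 1 to compound 3 (0.06 log units; within the scatter) stayed within the scatter, the new step is expected to be about as small, a number no higher from compound 2 to compound 4 (the limit leaves the size open). Compound 4 is therefore expected to sit near 250000 nM, most likely again as a limit, somewhere between 120000 nM and 500000 nM.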

Compound 4, half-maximal inhibitory concentration: 36000 nM
The estimate for compound 4 lay 6.9-fold (0.84 log units) above the measured number; measured number outside the range, below it.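

In this assay, the swap of fluoro for trifluoromethyl gave an at least 6.9-fold lower number from compound 2 to compound 4 (0.84 log units; beyond the scatter), so a change that made no clear difference on one core made a clear one on the other. The result on the first core therefore did not carry over to the second: the same change on two cores in this assay, a 1.2-fold lower number (0.06 log units; within the scatter) from compound 1 to compound 3 and an at least 6.9-fold lower number (0.84 log units; beyond the scatter) from compound 2 to compound 4, at least 6.0-fold (0.78 log units) apart, beyond the scatter of two such steps

Compound 2 is recorded only as a limit, >= 250000 nM, so this step has no exact size, and a single pair on each core sets no rule for the series. The compounds shown leave open why the two cores respond differently. They also leave open how a nitrile or a carboxylic acid on the same aromatic carbon would compare with trifluoromethyl on either core.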